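Benzyloxycarbonyl in Place of Trifluoromethyl

A few compounds are considered here, and "the series" means these few. Any claim that something is new, unique, unknown or untested is made for them only; others in the source may bear on it.

Among the compounds with values here, in a functional assay on MCF7 cells (Homo sapiens) for antiproliferative activity, read by MTT assay, with a stated time of 48 h (on this read-out higher numbers stand for weaker inhibition and lower numbers for stronger inhibition), compound 1 `Cc1ccc2[nH]c(-c3cn(-c4ccccc4)nc3-c3ccccc3)nc2c1` gives 5940 nM and compound 2 `FC(F)(F)c1ccc2[nH]c(-c3cn(-c4ccccc4)nc3-c3ccccc3)nc2c1` gives 2660 nM, the lower of the two numbers so far. Compound 3 `O=C(OCc1ccccc1)c1ccc2[nH]c(-c3cn(-c4ccccc4)nc3-c3ccccc3)nc2c1` carries benzyloxycarbonyl in place of trifluoromethyl on an aromatic carbon. Within the data shown here, the only measured step at this place, a 2.2-fold lower number from compound 1 to compound 2 (0.35 log units; beyond the scatter), is modest and involves no group resembling benzyloxycarbonyl, so it offers only a weak guide. A similarly modest change in this assay is therefore expected, leaning towards a higher number, and the estimated step is a 1.3-fold higher number from compound 2 to compound 3 (0.12 log units; within the scatter). For compound 3 the expected value is 3500 nM, with an estimated range of 900 nM to 12000 nM.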

Compound 3, half-maximal inhibitory concentration: 12600 nM
Estimate against measurement, compound 3: 3.6-fold (0.56 log units) below, and the stated range ends below it.
By their numbers in this assay, from the lowest: compound 2; then compound 1; then compound 3.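

In this assay, benzyloxycarbonyl at this position goes with weaker inhibition than either smaller group, with a 4.7-fold higher number from compound 2 to compound 3 (0.68 log units; beyond the scatter) and a 2.1-fold higher number from compound 1 to compound 3 (0.33 log units; beyond the scatter), both beyond the scatter. The position is therefore not indifferent to what sits on this aromatic carbon, and the change that brings in an aromatic ring and a carbonyl gives up the gain seen with trifluoromethyl. Nothing available explains this result. Going by these compounds, whether the carbonyl or the added aromatic ring goes with the rise stays open; a carboxylic acid or a methyl ester at this place would separate the two.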